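Chalcone thiazoles: three limits and a fourth analogue

The compounds below may be only part of what the source reports. "The series", "measured", "known", "first", "only" and "open" are said of these compounds alone.

Compound 1 `Cc1nc(Nc2ccc(Cl)cc2)sc1C(=O)/C=C/c1ccccc1`: in a functional assay on BGC-823 cells (Homo sapiens) for cytotoxicity, read by MTT assay (on this read-out lower numbers stand for stronger inhibition and higher numbers for weaker inhibition), compound 1 gives a limit of the assay, > 25000 nM.
Compound 2 `COc1cccc(/C=C/C(=O)c2sc(Nc3ccc(Cl)cc3)nc2C)c1`: in this assay compound 2 also gives only a limit, > 25000 nM.
Compound 3 `COc1cccc(/C=C/C(=O)c2sc(Nc3ccc(C)cc3)nc2C)c1`: in this assay compound 3 likewise gives only a limit, > 25000 nM.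

All three measured values sit at the same limit (the limit of > 25000 nM in this assay, at which 3 of the 3 values shown sit), so none of the steps among them can be read. From compound 2 to compound 1 the change is hydrogen in place of methoxy on an aromatic carbon, and the step is a step that the two limits leave unreadable from compound 2 to compound 1. The cores of compound 2 and compound 3 differ by methyl in place of chloro on an aromatic carbon, with the step that the two limits leave unreadable from compound 2 to compound 3.

Compound 4 `Cc1ccc(Nc2nc(C)c(C(=O)/C=C/c3ccccc3)s2)cc1` is not yet measured. It differs from compound 3 by hydrogen in place of methoxy on an aromatic carbon, the same change as from compound 2 to compound 1, at the same place. That earlier step could not be sized, and compound 3 itself shows only a limit, so the step from compound 3 to compound 4 is expected to be a step that the limit leaves unreadable from compound 3 to compound 4, resting only on those limits. Compound 4 is therefore expected to give about 50000 nM, most likely again as a limit rather than a number.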

Compound 4, half-maximal inhibitory concentration: > 25000 nM
Compound 4: a limit, no number (the forecaster's own chance of this, stated with the estimate: 85%); the middle value lies beyond the limit too.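

Compound 4 gives only a limit, so its steps from compound 3 and from compound 1 cannot be read: the limit of > 25000 nM in this assay, at which 4 of the 4 values shown sit.

The compounds shown leave open whether hydrogen in place of methoxy, or methyl in place of chloro, changes the potency at all.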